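Replacing the acetyl of compound 1 with a chlorinated aroyl group

The source may hold more compounds than are shown below. What is called first, only, known or untested is meant among the compounds shown, and "the series" means these compounds.

compound 1 `CC(=O)N1c2ccccc2CCC1C(=O)Nc1cc(C(F)(F)F)cc(C(F)(F)F)c1` — > 70000 nM
compound 2 `O=C(Nc1ccccc1C(F)(F)F)C1CCc2ccccc2N1C(=O)c1cccc(Cl)c1` — 526 nM
compound 3 `O=C(Nc1ccccc1C(F)(F)F)C1CCc2ccccc2N1C(=O)c1ccccc1` — 8090 nM

In a functional assay on ACHN cells (Homo sapiens) for cytotoxicity, read by sulforhodamine B assay, with a stated time of 72 h (a lower number here means a stronger inhibitor of growth, a higher number a weaker inhibitor of growth), compound 1 reaches only the limit of the assay, > 70000 nM, so no number is known for it; it sits at the limit of > 70000 nM in this assay, at which 1 of the 3 values shown sits. Compound 2 and compound 3 share the same core with a different anilide, and in this assay compound 2 gives 526 nM while compound 3 gives 8090 nM. Among the measured compounds shown here, the step of a 15-fold higher number from compound 2 to compound 3 (1.19 log units; beyond the scatter) is the only measured step, and it shows that removing a chloro from the aroyl ring weakens growth inhibition considerably.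

The unmeasured compound 4 is `O=C(Nc1cc(C(F)(F)F)cc(C(F)(F)F)c1)C1CCc2ccccc2N1C(=O)c1ccc(Cl)cc1`. It differs from compound 1 by 4-chlorophenyl in place of methyl on a carbonyl carbon. For the measured compounds named here, this change is larger than the measured one, and the only guidance is that compound 2, which carries a chloro on its aroyl ring, is the strongest of the three, and that compound 1, with an acetyl instead, gives no number. Compound 4 is therefore expected to move to a measurable number, with the step of an at least 23-fold lower number from compound 1 to compound 4 (1.36 log units; beyond the scatter) expected to be large and towards stronger inhibition. Compound 4 is estimated at 3000 nM, within a range of 300 nM to 30000 nM.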

Compound 4, concentration for 50% growth inhibition: 2570 nM
Estimate against measurement, compound 4: 1.2-fold (0.07 log units) above; low and high end bracket the measured number.
By their numbers in this assay, from the lowest: compound 2; then compound 4; then compound 3. At a limit, above all of these: compound 1.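

In this assay, the step from acetyl to (4-chlorophenyl)carbonyl on the amide-type nitrogen in a ring, with the anilide unchanged, gives an at least 27-fold lower number from compound 1 to compound 4 (1.43 log units; beyond the scatter). The earlier compounds shown here showed only that a chloro on an aroyl ring matters when the aroyl group is already in place, whereas this pair shows that the group on this carbonyl carbon can decide whether the shared core gives a measurable number at all. Compound 1 stands at > 70000 nM, which is a limit of the assay and not a number, so the step gives only a minimum size and compound 1 stands alone at this ceiling: the limit of > 70000 nM in this assay, at which 1 of the 4 values shown sits.

The compounds shown do not separate the contribution of the aromatic ring from that of its chloro on this anilide, and compound 2 and compound 4 differ in more than one place, so they cannot show how the placing of the chloro bears on the result. From the compounds shown here alone, how a cyclohexyl ring, a longer alkyl chain or an amine on this carbonyl carbon would read in this assay also remains open.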